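A few compounds are considered here, and "the series" means these few. Any claim that something is new, unique, unknown or untested is made for them only; others in the source may bear on it.

Measured so far in a functional assay on HL-60 cells (Homo sapiens) for inhibition, read by MTT assay, with a stated time of 72 h (on this read-out lower numbers stand for stronger inhibition and higher numbers for weaker inhibition), for this series:
- compound 1 `Cc1nc(-c2cccc(F)c2)c(C(=O)N2CCN(c3cccc(Cl)c3)CC2)o1` gives 33.7 nM
- compound 2 `COc1cccc(-c2nc(C)oc2C(=O)N2CCN(c3cccc(Cl)c3)CC2)c1` gives "not active" (no number reported)
- compound 3 `Cc1nc(-c2cccc(O)c2)c(C(=O)N2CCN(c3cccc(Cl)c3)CC2)o1` gives 105 nM

Compound 2 carries no single number, only the entry "not active" (no number reported) in this assay and so cannot be ranked numerically against the other two compounds.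

Compound 4 `COc1cc(-c2nc(C)oc2C(=O)N2CCN(c3cccc(Cl)c3)CC2)ccc1OP(=O)(O)O` keeps the methoxy group of compound 2 and adds one change, a group of 5 heavy atoms (4 oxygen, 1 phosphorus; no ring) in place of a hydrogen atom, on an aromatic carbon as its only structural difference. Going by the values given here, the one measured step is a 3.1-fold higher number from compound 1 to compound 3 (0.49 log units; beyond the scatter) and it is a different change, hydroxy in place of fluoro, so it bears on this case only indirectly. It does suggest that a change on this aromatic ring can be modest in size.

With no number for compound 2, no step size can be set. The expected direction is toward a measurable number, though compound 4 may also return no number. The working guess leans on compound 3 at 105 nM with a wide margin.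

Compound 4 is estimated at 300 nM with an expected range from 40 nM to 3000 nM in this series.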

Compound 4, half-maximal inhibitory concentration: 303 nM
Compound 4: middle estimate off by 1.0-fold (0.00 log units), on the low side; the range from low to high includes it.
By their numbers in this assay, from the lowest: compound 1; then compound 3; then compound 4.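

Going by these compounds alone, compound 2 carries no number in this assay, so no step to compound 4, at 303 nM, can be read. No available evidence accounts for this result. The compounds shown leave open how much the group added in compound 4 changes the number by itself.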